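The source may report more compounds than this note shows. Statements on the series, on what has been measured and on what is new or still open speak of the compounds shown alone.

Measured so far, each in an assay on HEK293 cells for binding affinity to prostaglandin E2 receptor EP4 subtype (Homo sapiens); a higher number here means a weaker inhibitor, a lower number a stronger inhibitor:
compound 1 `O=C(O)CCc1ccccc1-c1cccc(-c2ccccc2OCc2ccccc2)c1`: 1800 nM
compound 2 `O=C(O)CCCc1ccccc1-c1cccc(-c2ccccc2OCc2ccccc2)c1`: 2000 nM
compound 3 `O=C(O)CCc1ccccc1-c1cc(-c2ccccc2OCc2ccccc2)cs1`: 760 nM

Compound 2 stands at the high end of these three numbers. Its gap to compound 1 is small and within the scatter, a 1.1-fold higher number from compound 1 to compound 2 (0.05 log units; within the scatter); compound 3 gives a lower number, and that gap is beyond the scatter.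

Compound 4 `O=C(O)/C=C/c1ccccc1-c1cccc(-c2ccccc2OCc2ccccc2)c1` differs from compound 2 in one place: 2-carboxyethenyl in place of 3-carboxypropyl on an aromatic carbon. Among the measured compounds shown here, the only measured step that bears on this change is the chain lengthening a 1.1-fold higher number from compound 1 to compound 2 (0.05 log units; within the scatter), which moved the number hardly at all. For the measured compounds named here, no measured step introduces a double bond into this chain, so the effect of that part is untested. The expected step is therefore small, a 1.3-fold lower number from compound 2 to compound 4 (0.12 log units; within the scatter), with a wide range.

For compound 4 the estimate in this assay is 1500 nM, expected between 500 nM and 5000 nM.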

Compound 4, inhibition constant: 1700 nM
Beside the measured number, compound 4's estimate is 1.1-fold (0.05 log units) below it, and the stated range covers the measured number.
By their numbers in this assay, from the lowest: compound 3; then compounds 4, 1 and 2 (each within the scatter of the next).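

In this assay the double bond of 2-carboxyethenyl does not set it apart from the saturated chains on this aromatic carbon, ortho to a large group: a 1.1-fold lower number from compound 1 to compound 4 (0.02 log units; within the scatter) against 2-carboxyethyl and a 1.2-fold lower number from compound 2 to compound 4 (0.07 log units; within the scatter) against 3-carboxypropyl. Across compound 1, compound 2 and compound 4, neither chain length nor the double bond takes the number beyond the scatter. No evidence on hand bears on this result.

Open, on these data alone, is whether a tetrazole or a primary amide in place of the carboxylic acid would hold the number at this position. Also open, as far as these compounds go, is whether 2-carboxyethenyl on the core of compound 3 would stay as flat.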